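The source may report more compounds than this note shows. Statements on the series, on what has been measured and on what is new or still open speak of the compounds shown alone.

Values in a functional assay on MCF7 cells (Homo sapiens) for antiproliferative activity, with a stated time of 72 h; on this read-out higher numbers stand for an effect only at larger amounts of compound and lower numbers for an effect already at smaller amounts:
- compound 1 `O=C(NO)c1ccc(N(Cc2ccc(C3CCCCC3)cc2)C(=O)[C@H]2CCN2S(=O)(=O)c2c(F)c(F)c(F)c(F)c2F)cc1O`: 9700 nM
- compound 2 `NC(=O)c1ccc(N(Cc2ccc(C3CCCCC3)cn2)C(=O)[C@H]2CCN2S(=O)(=O)c2c(F)c(F)c(F)c(F)c2F)cc1O`: 4600 nM

Compound 2, at 4600 nM, holds the lower of the two numbers. Compound 1, at 9700 nM, lies higher, and that gap is beyond the usual scatter. Among the compounds with values here, the two compounds differ in more than one place, so their gap gives no clean step for any single change.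

Next in the series is compound 3 `O=C1NC(=O)c2cc(N(Cc3ccc(C4CCCCC4)cn3)C(=O)[C@H]3CCN3S(=O)(=O)c3c(F)c(F)c(F)c(F)c3F)ccc21`. It loses the 4-carbamoyl-3-hydroxyphenyl of compound 2 on the amide-type nitrogen, and the rest of the structure stays the same: a group of 11 heavy atoms (8 carbon, 1 nitrogen, 2 oxygen; one five-membered non-aromatic ring with 1 hetero atom, one six-membered aromatic ring of carbon only) in place of a group of 10 heavy atoms (7 carbon, 1 nitrogen, 2 oxygen; one six-membered aromatic ring of carbon only), on an amide-type nitrogen. The incoming group keeps the six-membered aromatic ring of carbon only and adds a five-membered non-aromatic ring with 1 hetero atom.

Within the data shown here, no measured pair isolates this exchange, so the data give no direct guide to its size or direction. In this assay the expected change is none beyond the scatter, with a slight lean toward a higher number. The estimate is a 1.3-fold higher number from compound 2 to compound 3 (0.12 log units; within the scatter). For compound 3 the expected value is 6000 nM, with an estimated range from 2000 nM to 18000 nM.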

Compound 3, half-maximal effective concentration: 7000 nM
The estimate for compound 3 lay 1.2-fold (0.07 log units) below the measured number, within the range that was stated.
By their numbers in this assay, from the lowest: compounds 2, 3 and 1 (each within the scatter of the next, the first and the last beyond it).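

On the amide-type nitrogen, the exchange of 4-carbamoyl-3-hydroxyphenyl for the incoming group, which keeps the six-membered aromatic ring of carbon only and adds a five-membered non-aromatic ring with 1 hetero atom, gives in this assay a 1.5-fold higher number from compound 2 to compound 3 (0.18 log units; within the scatter), so the two compounds cannot be told apart in this read-out. Within the data shown here, this is the first step that can be read at a single place, and it shows that the change from 2 hydrogen-bond donors to 1 hydrogen-bond donor, together with the added ring, comes with no shift beyond the scatter at this position. No accompanying measurement speaks to the reason for this result.

Open, on these data alone, is whether a plain phenyl, or a phenyl carrying a carboxylic acid or an amine in place of the carbamoyl, would also stay within the scatter of compound 2 on this amide-type nitrogen. Compound 1, at 9700 nM, differs from the other two compounds in more than one place, so what each of its differences contributes remains unresolved.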